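Cytotoxicity limits toward a pyrazine amide on Vero cells

The source may hold more compounds than are shown below. What is called first, only, known or untested is meant among the compounds shown, and "the series" means these compounds.

Compound 1 `CCN(CC)c1cc2[nH]c(C3CCCCC3)nc2cc1NC(=O)OCCOCCOC`: > 100 ug/mL
Compound 2 `COCCOC(=O)Nc1cc2nc(C3CCCCC3)[nH]c2cc1N1CCCC1`: > 100 ug/mL
Compound 3 `COc1ccc(C(=O)Nc2cc3nc(C4CCCCC4)[nH]c3cc2N2CCCC2)cc1`: > 100 ug/mL

In an ADME assay on Vero cells (Chlorocebus sabaeus) for cytotoxicity, read by resazurin assay, with a stated time of 3 days (a lower number here means a stronger inhibitor, a higher number a weaker inhibitor), compound 1 gives > 100 ug/mL, which is a limit of the assay and not a number. Compound 2 likewise shows only a limit, > 100 ug/mL. Compound 3 also stands at a limit, > 100 ug/mL. Within the data shown here, the single step between measured compounds, a step that the two limits leave unreadable from compound 2 to compound 3, cannot be read because the limit of > 100 ug/mL in this assay, at which 3 of the 3 values shown sit, holds both of its ends.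

Compound 4 `CCN(CC)c1cc2[nH]c(C3CCCCC3)nc2cc1NC(=O)c1cnccn1` differs from compound 1 by pyrazin-2-yl in place of 2-(2-methoxyethoxy)ethoxy on a carbonyl carbon. Among the measured compounds shown here, no measured step follows this change; the only step available sits on the same carbonyl carbon but concerns a different pair of groups and gives no readable size. What the three values share is that none of them falls below the limit, and the change to compound 4 is a modest exchange of one acceptor-bearing group for another at the same place. Compound 4 is therefore expected to remain at or near the limit, estimated at 100 ug/mL with a range from 50 ug/mL to 200 ug/mL. The step this estimate means, a number no higher from compound 1 to compound 4 (the limit leaves the size open), is expected to stay within the scatter.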

Compound 4, half-maximal inhibitory concentration: > 100 ug/mL
Compound 4: no number, only a limit (the forecaster's own chance of this, stated with the estimate: 85%); the middle value sits exactly at the limit.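

In this assay compound 4 gives > 100 ug/mL which is a limit of the assay and not a number. No new step can be read from compound 1 to compound 4, because both ends rest on the same limit: the limit of > 100 ug/mL in this assay, at which 4 of the 4 values shown sit. The compounds shown leave open how far the cytotoxicity of each lies past that limit.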